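The source may hold more compounds than are shown below. What is called first, only, known or untested is meant among the compounds shown, and "the series" means these compounds.

compound 1 `COC(=O)N[C@H](C(=O)N1CCC[C@H]1C(=O)Nc1ccc([C@H]2CC[C@H](c3ccc(NC(=O)[C@@H]4CCCN4C(=O)[C@@H](NC(=O)OC)C(C)C)cc3)N2c2ccc(C(F)(F)F)cc2)cc1)C(C)C` - 4.2 h
compound 2 `COC(=O)N[C@H](C(=O)N1CCC[C@H]1C(=O)Nc1ccc([C@@H]2CC[C@@H](c3ccc(NC(=O)[C@@H]4CCCN4C(=O)[C@@H](NC(=O)OC)[C@@H](C)OC)cc3)N2c2ccc(F)cc2)cc1)[C@@H](C)OC` - 0.6 h

In an ADME assay on the whole organism for metabolic stability, with Rattus norvegicus as the target, at a dose of 3 mg/kg by the intravenous route (a lower number here means that the compound disappears faster, a higher number that the compound lasts longer), compound 1 stands highest of the two measured compounds at 4.2 h while compound 2 gives 0.6 h and lies beyond the scatter from it. The next compound, compound 3 `COC(=O)N[C@H](C(=O)N1CCC[C@H]1C(=O)Nc1ccc([C@H]2CC[C@H](c3ccc(NC(=O)[C@@H]4CCCN4C(=O)[C@@H](NC(=O)OC)C(C)C)cc3)N2c2ccc(F)cc2)cc1)C(C)C`, differs from compound 1 in one place, with fluoro in place of trifluoromethyl on an aromatic carbon para to a large group. Within the data shown here, no measured pair shows this change alone, so the data offer no direct guide to its size in this assay and any forecast stays tentative. A step within the scatter is expected, with a slight lean toward a lower number. The estimated 1.4-fold lower number from compound 1 to compound 3 (0.15 log units; within the scatter) is accordingly small and downward. For compound 3 the half-life is estimated at 3 h with an expected range from 1.3 h to 6.5 h in this measurement.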

Compound 3, half-life: 3.3 h
Compound 3: middle estimate off by 1.1-fold (0.04 log units), on the low side, and the stated range covers the measured number.
By their numbers in this assay, from the lowest: compound 2; then compounds 3 and 1 (each within the scatter of the next).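

In this assay there is a 1.3-fold lower number from compound 1 to compound 3 (0.10 log units; within the scatter) when fluoro takes the place of trifluoromethyl on an aromatic carbon para to a large group. Among these compounds, this is the first reading of this change alone, and it shows that the 4-(trifluoromethyl)phenyl to 4-fluorophenyl exchange, with three fewer heavy atoms at this position, gives a step that stays within the scatter. No measurement at hand bears on why the half-life responds in this way.

The compounds shown leave open whether a nitrile, an amine or a carboxylic acid on this aromatic carbon would also stay within the scatter of compound 1. They also leave open whether the same exchange would give a step of similar size on the core of compound 2.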